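The compounds below may be only part of what the source reports. "The series", "measured", "known", "first", "only" and "open" are said of these compounds alone.

Notes on the series, step from compound 2 to compound 3.

Of the compounds shown here, two have a number so far. Compound 1 `CN1CCN(c2ccc(C3=NN(C(=O)c4ccc(F)cc4)C(c4ccc(N(C)C)cc4)C3)cc2)CC1` carries a 4-fluorophenyl on the carbonyl carbon and a methylpiperazinyl-substituted phenyl on the ring; in a functional assay on HCC1806 cells (Homo sapiens) for inhibition, read by sulforhodamine B assay, tested at 10 uM (on this read-out lower numbers stand for less inhibition and higher numbers for more inhibition at the one concentration tested (going by the name of the read-out)), compound 1 gives 31.8%. Compound 2 `COC(=O)CC(=O)N1N=C(c2ccc(-n3cncn3)cc2)CC1c1ccc(N(C)C)cc1` carries instead a (methoxycarbonyl)methyl on the carbonyl carbon and a triazolyl-substituted phenyl; in this assay compound 2 gives -7.8%, the lowest of the two numbers, with compound 1 the nearest and higher by a gap beyond the scatter. For the measured compounds named here, no pair differing in one place has been measured, so no single step is known.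

Compound 3 `CN(C)c1ccc(C2CC(c3ccc(-n4cncn4)cc3)=NN2C(=O)c2ccc(F)cc2)cc1` is the next compound to be measured in this assay. It differs from compound 2 in one place: 4-fluorophenyl in place of (methoxycarbonyl)methyl on a carbonyl carbon. Compound 3 thus shares the acyl part of compound 1 and the triazolyl-phenyl of compound 2, so the two numbers above bracket what can be said.

For compound 3 a step of a number 25.8 percentage points higher from compound 2 to compound 3 (beyond the scatter) is expected, upward and beyond the scatter, taking it toward the value of compound 1. The estimate for compound 3 in this assay is 18%, with a range from -2% to 38%.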

Compound 3, a percentage reported as inhibition, at one concentration (the size of the read-out at that concentration, not a potency): 15.6%
Compound 3: the middle estimate sits 2.4 percentage points above what was measured; measured number inside the range.
By their numbers in this assay, from the lowest: compound 2; then compound 3; then compound 1.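

In this assay, the acyl place now has its first single-change reading: 4-fluorophenyl in place of (methoxycarbonyl)methyl on the carbonyl carbon gives a number 23.4 percentage points higher from compound 2 to compound 3 (beyond the scatter). The aromatic substituent has one as well, since 1H-1,2,4-triazol-1-yl in place of 4-methylpiperazin-1-yl on an aromatic carbon gives a number 16.2 percentage points lower from compound 1 to compound 3 (beyond the scatter), so each of the two places moves the number on its own, and the 4-fluorophenyl carbonyl keeps a positive reading with either aromatic substituent. No measurement bears on why either change shifts the inhibition.

From the compounds shown here alone, the acyl step swaps a whole group, so it remains open whether the rise follows the aromatic ring, the fluorine or the departure of the (methoxycarbonyl)methyl, a question that a plain phenyl, a short alkyl such as methyl, or a carboxylic acid on the carbonyl carbon could separate. Also open, going by these compounds, are whether the two steps hold when combined on other partners and how a different amine on the aromatic carbon, such as morpholine, would read against 4-methylpiperazin-1-yl.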